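The compounds below may be only part of what the source reports. "The series", "measured", "known", "first", "only" and "open" are said of these compounds alone.

In a functional assay on Vero cells (Chlorocebus sabaeus) for inhibition (on this read-out lower numbers stand for stronger inhibition and higher numbers for weaker inhibition), compound 2 `Clc1ccc(Cn2cnc3c(-c4ccco4)ncnc32)cc1` stands at > 62.5 ug/mL, which is a limit and not a number. Compound 3 `Clc1ccc(Cn2cnc3c(-c4ccco4)ncnc32)cc1Cl` differs from it by chloro in place of hydrogen on an aromatic carbon. Compound 1 `CSc1ccc(Cn2cnc3c(-c4ccco4)ncnc32)cc1` gives 6.9 ug/mL. Among the measured compounds shown here, the one measured step that bears on this is an at least 9.0-fold higher number from compound 1 to compound 2 (0.95 log units; beyond the scatter), beyond the scatter, but it swaps methylsulfanyl for chloro and adds no second chloro. In this assay, the expected step is an at least 1.0-fold lower number from compound 2 to compound 3 (0.01 log units; that floor lies within the scatter), with nothing beyond the scatter anticipated and the read-out expected to stay weak. Compound 3 is estimated at 60 ug/mL, with an expected range of 20 ug/mL to 125 ug/mL.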

Compound 3, half-maximal inhibitory concentration: > 10 ug/mL
Compound 3 ended at the assay's limit; the forecaster's own chance of this, stated with the estimate: 60%; the middle value does not contradict the limit.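

Compound 2 and compound 3 both stand as limits and not as numbers in this assay, and the step between them cannot be read. The compounds shown leave open whether chloro in place of hydrogen on an aromatic carbon changes inhibition at all.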